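The source may hold more compounds than are shown below. What is called first, only, known or untested is meant among the compounds shown, and "the series" means these compounds.

Compound 1 `CO[C@H]1O[C@H](CNC(=O)CN(Cc2ccccc2)C(C)=O)[C@@H](OS(=O)(=O)O)[C@H](OS(=O)(=O)O)[C@@H]1OS(=O)(=O)O`: in an assay on isolated protein for binding affinity to fibroblast growth factor 2 (Homo sapiens), read by surface plasmon resonance (a higher number here means weaker binding, a lower number tighter binding), compound 1 gives 192000 nM.
Compound 2 `CO[C@H]1O[C@H](CNC(=O)CN(CCOS(=O)(=O)O)C(C)=O)[C@@H](OS(=O)(=O)O)[C@H](OS(=O)(=O)O)[C@@H]1OS(=O)(=O)O`: in this assay compound 2 gives 240000 nM.
Compound 3 `CO[C@H]1O[C@H](CNC(=O)CN(C(C)=O)C2CCCCCC2)[C@@H](OS(=O)(=O)O)[C@H](OS(=O)(=O)O)[C@@H]1OS(=O)(=O)O`: in this assay compound 3 gives 410000 nM.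

Of the three measured compounds, compound 3 has the highest number. One of its steps, a 1.7-fold higher number from compound 2 to compound 3 (0.23 log units; within the scatter), stays within the scatter; the other, a 2.1-fold higher number from compound 1 to compound 3 (0.33 log units; beyond the scatter), lies just beyond it, so compound 3 is set apart only from compound 1. The step of a 1.3-fold higher number from compound 1 to compound 2 (0.10 log units; within the scatter), between the two others, is within the scatter.

Compound 4 `CO[C@H]1O[C@H](CNC(=O)CN(C(C)=O)c2ccccc2)[C@@H](OS(=O)(=O)O)[C@H](OS(=O)(=O)O)[C@@H]1OS(=O)(=O)O` differs from compound 3 by phenyl in place of cycloheptyl on an amide-type nitrogen. The measured step that bears most directly on this change is a 2.1-fold higher number from compound 1 to compound 3 (0.33 log units; beyond the scatter), where an aromatic ring on the amide-type nitrogen, carried through one chain carbon, gave the lower number and the cycloheptyl the higher one. Placing an aromatic ring directly on that nitrogen is a related but not identical change, and nothing measured tells how the missing chain carbon matters. A modest return toward the number of compound 1 is therefore the most that can be expected.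

Compound 4 is thus expected to show a 1.8-fold lower number from compound 3 to compound 4 (0.25 log units; within the scatter), a step that may not clear the scatter. For compound 4 the estimate in this assay is 230000 nM, with a range from 110000 nM to 480000 nM.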

Compound 4, dissociation constant: 480000 nM
For compound 4 the middle estimate is 2.1-fold (0.32 log units) below the measured one; low and high end bracket the measured number.
By their numbers in this assay, from the lowest: compounds 1, 2, 3 and 4 (each within the scatter of the next, the first and the last beyond it).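

In this assay the change from cycloheptyl to phenyl on the amide-type nitrogen gives a 1.2-fold higher number from compound 3 to compound 4 (0.07 log units; within the scatter) and so does not separate the two rings, which shows that an aromatic ring set directly on that nitrogen does not keep compound 4 with compound 1. Phenyl and benzyl, which differ by one chain carbon, give a 2.5-fold higher number from compound 1 to compound 4 (0.40 log units; beyond the scatter) in a modest step, whereas phenyl in place of 2-(sulfooxy)ethyl gives a 2.0-fold higher number from compound 2 to compound 4 (0.30 log units; within the scatter) and remains unresolved, so among the four compounds only compound 1 stands apart from compound 3 and compound 4, and compound 2 stands apart from none. No independent evidence accounts for these steps.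

The compounds shown leave open whether a longer chain between the amide-type nitrogen and the phenyl ring, as in 2-phenylethyl, would take the number further from that of compound 4 than benzyl does. They also leave open how an amine or a carboxylic acid carried on that nitrogen would compare with benzyl, or whether either would give a step clearly beyond the scatter.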